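This account rests on a few compounds, and the source may have more. Where it says the series, first, only, none or still open, it means among the compounds named here.

In a functional assay on IMR-32 cells (Homo sapiens) for cytotoxicity, read by MTT assay, tested at 60 ug/mL (a lower number here means less inhibition, a higher number more inhibition at the concentration tested (going by the name of the read-out)), compound 1 `CC(C)NC(=O)CCC(NS(=O)(=O)c1cc(Cl)ccc1Cl)C(=O)NC(C)C` gives 16.7%, and compound 2 `O=C(CCC(NS(=O)(=O)c1cc(Cl)ccc1Cl)C(=O)NCc1ccccc1)NCc1ccccc1` gives 13.4%. Compound 3 `O=C(CCC(NS(=O)(=O)c1ccc(Br)cc1)C(=O)NCc1ccccc1)NCc1ccccc1` shares the core of compound 2 but carries a different group on the sulfonyl sulfur; in this assay compound 3 gives "not determined" (no result reported), so it stands without a number. Compound 4 `O=C(CCC(NS(=O)(=O)c1ccc(Cl)c(Cl)c1)C(=O)NCc1ccccc1)NCc1ccccc1` differs from compound 3 in one place: 3,4-dichlorophenyl in place of 4-bromophenyl on a sulfonyl sulfur. Because compound 3 has no value, the step from compound 3 to compound 4 cannot be read from the data; going by compound 2, whose value is 13.4%, the expected change across this step in this assay is none beyond the scatter. Compound 4 is therefore expected to give 15% in this assay, within the range 4% to 28%.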

Compound 4, a percentage reported as inhibition, at one concentration (the size of the read-out at that concentration, not a potency): 11.4%
Compound 4: the middle estimate sits 3.6 percentage points above what was measured; measured number inside the range.
By their numbers in this assay, from the lowest: compounds 4, 2 and 1 (each within the scatter of the next).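

In this assay, 3,4-dichlorophenyl in place of 2,5-dichlorophenyl on a sulfonyl sulfur gives a number 2 percentage points lower from compound 2 to compound 4 (within the scatter), so moving from one dichlorophenyl group to the other at this position leaves the read-out unchanged within the scatter. Going by these compounds, the step from compound 3 to compound 4 cannot be read, and the effect of 4-bromophenyl stays unknown. No measurement shown here offers an explanation for this result. The compounds shown leave open whether a non-aromatic group such as methyl, or a phenyl ring bearing a carboxylic acid or an amine, on the sulfonyl sulfur would give a different number.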